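The source may hold more compounds than are shown below. What is called first, only, known or untested is meant among the compounds shown, and "the series" means these compounds.

Of the compounds shown here, two have so far been measured in an in vitro functional assay on 1321-N1 cells for antagonist activity at transient receptor potential cation channel subfamily V member 1 (Homo sapiens), read by FLIPR and calcium flux; a higher number here means a weaker inhibitor, a lower number a stronger inhibitor. Compound 1 `CC(C)(C)c1ccc(NC(=O)c2ccc(-c3ccccn3)cc2)cc1` gives 42 nM, and compound 2 `CC(C)(C)c1ccc(NC(=O)C2=CCN(c3ncccc3C(F)(F)F)CC2)cc1` gives 6 nM. Compound 2 therefore holds the lower of the two numbers, and the gap between the two values lies beyond the usual scatter of this kind of measurement.

Compound 3 `O=C(Nc1ccc(Cl)cc1)C1=CCN(c2ncccc2C(F)(F)F)CC1` has not yet been measured. It keeps everything in compound 2 except one change: chloro in place of tert-butyl on an aromatic carbon. For the measured compounds named here, no measured pair in this small set shows that exact change, so its effect cannot be read from any earlier step and must be judged from the structures alone. The swap from tert-butyl to chloro is expected to cost some potency, with the step estimated at a 5.0-fold higher number from compound 2 to compound 3 (0.70 log units; beyond the scatter), towards a weaker inhibitor. Compound 3 is therefore expected to give about 30 nM in this assay, with a plausible range from 8 nM to 120 nM.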

Compound 3, half-maximal inhibitory concentration: 19 nM
The estimate for compound 3 lay 1.6-fold (0.20 log units) above the measured number, and the stated range covers the measured number.
By their numbers in this assay, from the lowest: compound 2; then compound 3; then compound 1.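

For the compounds shown here, compound 2 and compound 3 are the first pair in this assay to differ in one place only, so the group on the aromatic carbon, para to a large group, can now be judged on its own. Replacing tert-butyl, with 4 heavy atoms, by chloro, with 1 heavy atom, gives a 3.2-fold higher number from compound 2 to compound 3 (0.50 log units; beyond the scatter), a modest loss of potency that lies beyond the scatter. The position therefore accepts the much smaller group without losing all activity, as compound 3 still gives 19 nM in this test.

Going by these compounds, whether a methoxy group, a bromine or an amine at this position would do better or worse remains open, as does whether the same swap would cost as much on the core of compound 1. No measurement shown here accounts for the size of this step.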